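Aryl swap on the ring nitrogen of the shared core

A few compounds are considered here, and "the series" means these few. Any claim that something is new, unique, unknown or untested is made for them only; others in the source may bear on it.

Measured so far:
compound 1 `Cc1cccc(N2C(=O)CSC2c2cccc(C(=O)NCCCCc3ccccc3)c2)c1`, 93.2 nM
compound 2 `CCOc1ccccc1N1C(=O)C(C)SC1c1cccc(C(=O)NCCCCc2ccccc2)c1`, 71.6 nM

In a functional assay on HOS-TE85 cells (Homo sapiens) for inhibition, read by CCK-8 assay, with a stated time of 72 h (on this read-out lower numbers stand for stronger inhibition and higher numbers for weaker inhibition), compound 1 gives 93.2 nM, the highest of the two numbers shown; the nearest is compound 2 with 71.6 nM, a gap that lies within the scatter, so no order between them is claimed. Compound 3 `COc1ccc(N2C(=O)CSC2c2cccc(C(=O)NCCCCc3ccccc3)c2)c(OC)c1` is not yet measured. It differs from compound 1 as follows: 2,4-dimethoxyphenyl in place of 3-methylphenyl on an amide-type nitrogen in a ring. Going by the values given here, no step between measured compounds covers this change, so nothing beyond the scatter is expected in this assay: the step of a 1.2-fold higher number from compound 1 to compound 3 (0.07 log units; within the scatter) is estimated as small. Compound 3 is expected near 110 nM, within 40 nM to 320 nM.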

Compound 3, half-maximal inhibitory concentration: 90.4 nM
Compound 3: middle estimate off by 1.2-fold (0.09 log units), on the high side; the measured number falls inside the stated range.
By their numbers in this assay, from the lowest: compounds 2, 3 and 1 (each within the scatter of the next).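

In this assay, going by these compounds alone, the one-place step is a 1.0-fold lower number from compound 1 to compound 3 (0.01 log units; within the scatter) and gives the first direct reading at the amide-type ring nitrogen. Here 2,4-dimethoxyphenyl cannot be told apart from 3-methylphenyl, although only the entering group carries hydrogen-bond acceptors and it has more heavy atoms. No measurement at hand accounts for this result.

Open, on these data alone, is whether a different group on this nitrogen, such as a pyridyl ring or a phenyl bearing a carboxylic acid, would give a step beyond the scatter. As far as these compounds go, compound 2 differs from compound 1 and compound 3 in more than one place, so the separate contribution of each of its changes also stays open.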